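The compounds below may be only part of what the source reports. "The series", "measured", "known", "first", "only" and "open" are said of these compounds alone.

In a functional assay on BGC-823 cells (Homo sapiens) for inhibition, read by MTT assay, with a stated time of 72 h (on this read-out lower numbers stand for stronger inhibition and higher numbers for weaker inhibition), three compounds sharing one core have been measured. Compound 1 `Cc1cc(N2CC[C@@H](C)[C@@H](N(C)c3ncnc4[nH]ccc34)C2)n2nc(SCC3CC3)nc2n1` gives 36500 nM. Compound 2 `C[C@@H]1CCN(c2cc(-c3ccccc3)nc3ncnn23)C[C@@H]1N(C)c1ncnc2[nH]ccc12` returns only a limit of the assay, > 100000 nM. Compound 3 `Cc1cc(N2CC[C@@H](C)[C@@H](N(C)c3ncnc4[nH]ccc34)C2)n2nc(SCc3csc4ccc(Cl)cc34)nc2n1` also returns only a limit, > 100000 nM, and not a number. Compound 3 therefore stands at the limit of > 100000 nM in this assay, at which 2 of the 3 values shown sit.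

Compound 4 `C=CCSc1nc2nc(C)cc(N3CC[C@@H](C)[C@@H](N(C)c4ncnc5[nH]ccc45)C3)n2n1` has not yet been measured. It differs from compound 3 in one place: vinyl in place of 5-chloro-1-benzothiophen-3-yl on a saturated chain carbon bound to a sulfur. Vinyl takes the place of 5-chloro-1-benzothiophen-3-yl on a saturated chain carbon bound to a sulfur, so that (5-chloro-1-benzothiophen-3-yl)methyl gives way to allyl.

Among the compounds with values here, only one measured step bears on this change: an at least 2.7-fold higher number from compound 1 to compound 3 (0.43 log units; beyond the scatter). It brought in the same 5-chloro-1-benzothiophen-3-yl at the same place, replacing cyclopropyl, and its size is known only as a bound. Compound 4 loses that group again, so the step is expected to run the other way, towards lower numbers in this assay, and to end near the value of compound 1, 36500 nM. The expected step is an at least 2.5-fold lower number from compound 3 to compound 4 (0.39 log units; beyond the scatter), modest in size and uncertain because compound 3 rests on > 100000 nM. Compound 4 is estimated at 40000 nM, with an expected range from 15000 nM to 100000 nM.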

Compound 4, half-maximal inhibitory concentration: 40900 nM
For compound 4 the middle estimate is 1.0-fold (0.01 log units) below the measured one, and the stated range covers the measured number.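

In this assay, vinyl in place of 5-chloro-1-benzothiophen-3-yl on a saturated chain carbon bound to a sulfur gives a step beyond the scatter (an at least 2.4-fold lower number from compound 3 to compound 4 (0.38 log units; beyond the scatter)), so the effect of this group at this place is now seen from two sides, on its way in and on its way out. Vinyl and cyclopropyl at the same place cannot be told apart in this assay (a 1.1-fold higher number from compound 1 to compound 4 (0.05 log units; within the scatter)), which gives a second pair of compounds at this position and shows that the change from one of these two groups to the other leaves the read-out within the scatter. From the compounds shown here alone, compound 3 holds only a limit and not a number, so the full size of the step away from it remains unknown: the limit of > 100000 nM in this assay, at which 2 of the 4 values shown sit.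

The compounds shown do not tell whether any group on this sulfur brings the number in this assay down beyond the level shared by compound 1 and compound 4. Going by these compounds, a longer chain, an amine or a carboxylic acid at this place remains open.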